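Neopentyl in place of pentan-3-yl: a clearance estimate

A few compounds are considered here, and "the series" means these few. Any claim that something is new, unique, unknown or untested is made for them only; others in the source may bear on it.

Of the compounds shown here, two have numbers so far in an in vitro ADME assay on microsomes from liver (Homo sapiens) for metabolic stability; on this read-out lower numbers stand for slow clearance and higher numbers for fast clearance. Compound 1 `Cc1ccc([C@H](C(=O)N(C)C)N2C(=O)[C@@H](C3Cc4ccccc4C3)NC(=O)[C@H]2CC(C)C)cn1` gives 11000 mL.min-1.g-1. Going by the values given here, compound 2 `CCC(CC)[C@@H]1C(=O)N[C@H](C2Cc3ccccc3C2)C(=O)N1[C@@H](C(=O)N(C)C)c1ccc(C)nc1` gives 11 mL.min-1.g-1, the lowest of the two numbers and far beyond the scatter from its only neighbour. Compound 3 `Cc1ccc([C@H](C(=O)N(C)C)N2C(=O)[C@@H](C3Cc4ccccc4C3)NC(=O)[C@H]2CC(C)(C)C)cn1` carries neopentyl in place of pentan-3-yl on a saturated ring carbon.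

Among the compounds with values here, only one measured step bears on this change: a 1000-fold lower number from compound 1 to compound 2 (3.00 log units; beyond the scatter), with pentan-3-yl in place of isobutyl on that same ring carbon. That step is large, so this assay responds strongly to the group at this carbon in these two compounds. Within the data shown here, no measured compound carries neopentyl, and a single step cannot show how the number follows the shape of the chain. Neopentyl matches pentan-3-yl in the count, while its name reads closer to the isobutyl of compound 1 at 11000 mL.min-1.g-1, so part of that large step may be lost. A rise is therefore expected, with an estimated 9.1-fold higher number from compound 2 to compound 3 (0.96 log units; beyond the scatter), only part of the way back. For compound 3 the estimate is 100 mL.min-1.g-1, with an expected range of 12 mL.min-1.g-1 to 1500 mL.min-1.g-1.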

Compound 3, intrinsic clearance in microsomes: 6 mL.min-1.g-1
The estimate for compound 3 lay 17-fold (1.22 log units) above the measured number; the measured number lies below the stated range.
By their numbers in this assay, from the lowest: compounds 3 and 2 (each within the scatter of the next); then compound 1.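

In this assay, swapping pentan-3-yl for neopentyl, two chains with the same carbon count, leaves no readable difference: a 1.8-fold lower number from compound 2 to compound 3 (0.26 log units; within the scatter), so at this ring carbon the two branched shapes cannot be told apart. Methyl in place of hydrogen on the isobutyl chain gives a 1800-fold lower number from compound 1 to compound 3 (3.26 log units; beyond the scatter), so this single carbon on the chain accounts for a step as large as the one seen earlier with pentan-3-yl, and among the three chains only the isobutyl of compound 1 stands at a high number. Nothing at hand gives a reason for this sharp dependence on the chain.

Still open, on these data alone, is whether the low numbers need a chain of this size, which a smaller group such as ethyl or a ring such as cyclopentyl at the same carbon would test. Also open, as far as these compounds go, is whether a chain carrying a hydroxyl group or an amine would hold the number as low as neopentyl and pentan-3-yl do.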